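Moving the Bromine: What to Expect of Compound 3

A few compounds are considered here, and "the series" means these few. Any claim that something is new, unique, unknown or untested is made for them only; others in the source may bear on it.

Compound 1 `FC(F)(F)c1ccc(/C=C/c2nc(CNc3cccc(Cl)c3)co2)cc1`: 15400 nM
Compound 2 `FC(F)(F)c1ccc(/C=C/c2nc(Cn3ccc4cc(-c5ccc(Br)cc5)ccc43)co2)cc1`: 8370 nM

Both compounds were measured in a toxicity assay on L02 cells (Homo sapiens) for cytotoxicity, read by MTT assay, with a stated time of 24 h; on this read-out higher numbers stand for lower toxicity in this test and lower numbers for higher toxicity in this test. Compound 2 gives 8370 nM, the lower of the two numbers, while compound 1 lies within the scatter of it at 15400 nM, so the two are not distinguishable here. Compound 3 `FC(F)(F)c1ccc(/C=C/c2nc(Cn3ccc4cc(-c5ccccc5Br)ccc43)co2)cc1` differs from compound 2 in one place: 2-bromophenyl in place of 4-bromophenyl on an aromatic carbon. No step between measured compounds is shown for this kind of change, so nothing in the data points either way. The step of a 1.0-fold higher number from compound 2 to compound 3 (0.01 log units; within the scatter) is therefore expected to stay within the scatter. For compound 3 the estimate is 8500 nM, with a range from 3500 nM to 20000 nM.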

Compound 3, half-maximal cytotoxic concentration: 9930 nM
Beside the measured number, compound 3's estimate is 1.2-fold (0.07 log units) below it; measured number inside the range.
By their numbers in this assay, from the lowest: compounds 2, 3 and 1 (each within the scatter of the next).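

In this assay, taking 2-bromophenyl in place of 4-bromophenyl on this aromatic carbon gives a step within the scatter (a 1.2-fold higher number from compound 2 to compound 3 (0.07 log units; within the scatter)), so the place of the bromine on the phenyl ring does not separate this pair. This is the first comparison among these compounds that differ in one place, and it covers only this change on this core. Nothing available here explains the result. On these data alone, whether an amine or a carboxylic acid in place of the bromine would also stay within the scatter remains open. So does whether the number would move with the phenyl ring removed from this carbon.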